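This account rests on a few compounds, and the source may have more. Where it says the series, first, only, none or still open, it means among the compounds named here.

Working notes on a diaryl urea series read in a functional assay on HCC827 cells (Homo sapiens) for inhibition, read by MTT assay, with a stated time of 48 h, tested at 10 uM; on this read-out lower numbers stand for less inhibition and higher numbers for more inhibition at the one concentration tested (going by the name of the read-out).

Compound 1 `Cc1ccc(Nc2cc(NC(=O)Nc3c(Cl)cccc3Cl)ncn2)cc1F` is the reference of the set; in this assay compound 1 gives 85.3%. Compound 2 `COc1ccc(F)cc1Nc1cc(NC(=O)Nc2c(Cl)cccc2Cl)ncn1` differs from it in one place, (5-fluoro-2-methoxyphenyl in place of 3-fluoro-4-methylphenyl on a nitrogen on an aromatic ring), and in this assay compound 2 gives 78%. The step is a number 7.3 percentage points lower from compound 1 to compound 2 (within the scatter), so the two numbers are not separated by the measurement.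

Compound 3 `COc1cc(NC(=O)Nc2cc(Nc3ccc(C)c(F)c3)ncn2)cc(OC)c1` carries a different core; how the core of compound 3 differs from the core of compound 1 is not broken down here. In this assay compound 3 gives 72%. Against compound 2 this sits within the scatter; against compound 1 it is the lower of the two numbers, and that gap lies beyond the scatter.

Compound 4 `COc1cc(NC(=O)Nc2cc(Nc3cc(F)ccc3OC)ncn2)cc(OC)c1` has not yet been measured in this assay. It stands to compound 3 as compound 2 stands to compound 1: 5-fluoro-2-methoxyphenyl in place of 3-fluoro-4-methylphenyl on a nitrogen on an aromatic ring. The place of the change reads the same in both pairs, so this is the same change made on the second core. Among the compounds with values here, the only measured precedent for it is the step from compound 1 to compound 2, a number 7.3 percentage points lower from compound 1 to compound 2 (within the scatter), which stayed within the scatter. On that basis a step of similar size, a number 6 percentage points lower from compound 3 to compound 4 (within the scatter), is expected from compound 3 to compound 4. For compound 4 the estimated number in this assay is 66%, with the likely range running from 52% to 78%.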

Compound 4, a percentage reported as inhibition, at one concentration (the size of the read-out at that concentration, not a potency): 59%
Compound 4: the middle estimate sits 7 percentage points above what was measured, and the stated range covers the measured number.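

In this assay the change to 5-fluoro-2-methoxyphenyl from 3-fluoro-4-methylphenyl, carried over to the second core, gives a number 13 percentage points lower from compound 3 to compound 4 (beyond the scatter), and the steps on the two cores are not separated by the measurement: the same change on two cores in this assay, a number 7.3 percentage points lower (within the scatter) from compound 1 to compound 2 and a number 13 percentage points lower (beyond the scatter) from compound 3 to compound 4, 5.7 percentage points apart, within the scatter of two such steps. Read together, the two steps are compatible with a change of similar size on both cores, even though only the step on the second core stands beyond the scatter by itself. This rests on two pairs in one read-out at a single concentration, so it does not show that the change would behave alike on any further core, and it gives neither a potency nor a reason for the step.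

The change on the other side of the urea is read only once, as a number 19 percentage points lower from compound 2 to compound 4 (beyond the scatter), with 3,5-dimethoxyphenyl in place of 2,6-dichlorophenyl on an amide-type nitrogen, and that single pair says nothing about other groups at that place. Also open, on these data alone, is how either core would take a phenyl ring carrying a carboxylic acid or an amine in place of the methoxy group on the nitrogen on the aromatic ring.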